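Shortening the amide substituent from a chain to a ring

The source may report more compounds than this note shows. Statements on the series, on what has been measured and on what is new or still open speak of the compounds shown alone.

Measured compounds:
compound 1, `CNC(=O)c1cc(C(=O)NCCC2CCOCC2)cn(Cc2ccccc2)c1=O`, 3.6
compound 2, `CNC(=O)c1cc(C(=O)NC2CCC2)cn(Cc2ccccn2)c1=O`, 2.2
compound 3, `CNC(=O)c1cc(C(=O)NC2CC2)cn(Cc2cccc3cc[nH]c23)c1=O`, 3.7

In a physicochemical assay for lipophilicity, at pH 7.4 (on this read-out lower numbers stand for lower lipophilicity and higher numbers for higher lipophilicity), compound 1 stands second highest of the three numbers. Its nearest neighbour is compound 3, whose value lies within the scatter of that of compound 1, so the two cannot be ordered; compound 2 lies well below both, beyond the scatter. Compound 4, `CNC(=O)c1cc(C(=O)NC2CCOCC2)cn(Cc2ccccc2)c1=O`, has not been measured in this assay. It differs from compound 1 in one place: oxan-4-yl in place of 2-(oxan-4-yl)ethyl on an amide-type nitrogen. The 2-(oxan-4-yl)ethyl group on the amide-type nitrogen leaves and oxan-4-yl enters there. The author expects a moderate downward step from compound 1 to compound 4 in this assay, beyond the scatter, of about a number 0.70 log units lower from compound 1 to compound 4 (beyond the scatter). Compound 4 is therefore estimated at 2.9, with a range from 2.4 to 3.4.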

Compound 4, distribution coefficient: 2.8
The estimate for compound 4 lay 0.10 log units above the measured number; measured number inside the range.
By their numbers in this assay, from the lowest: compound 2; then compound 4; then compounds 1 and 3 (each within the scatter of the next).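

Within the data shown here, the pair gives the first step in this set that can be read at a single place: in this assay, oxan-4-yl in place of 2-(oxan-4-yl)ethyl on the amide-type nitrogen gives a number 0.80 log units lower from compound 1 to compound 4 (beyond the scatter). Both groups carry the same six-membered non-aromatic ring with 1 hetero atom, so the two differ only in the ethyl link. No measurement at hand accounts for the size of this step. Still open, from the compounds shown here alone, is whether a longer chain, such as 3-(oxan-4-yl)propyl, would extend the step in the opposite direction. Also open, going by these compounds, is how an amine in the ring, as in piperidin-4-yl, would compare with oxan-4-yl at this place.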